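Moving a trifluoromethoxy group on a bile acid receptor ligand

The source may hold more compounds than are shown below. What is called first, only, known or untested is meant among the compounds shown, and "the series" means these compounds.

Four related compounds are compared in an assay on isolated protein with Bile acid receptor (Homo sapiens) as the target; a higher number here means that more compound is needed for the effect, a lower number that less compound is needed. Compound 1 `COC(=O)/C=C/c1cccc(N(Cc2ccc(-c3ccc(OC(F)(F)F)cc3)cc2)C(=O)C(C)C)c1` gives 219 nM. Compound 2 `COC(=O)/C=C/c1cccc(N(Cc2ccc(-c3cccc(OC(F)(F)F)c3)cc2)C(=O)C(C)C)c1` gives 247 nM. Compound 3 `COC(=O)/C=C/c1cccc(N(Cc2ccc(-c3ccc(OC(F)(F)F)cc3)cc2)C(=O)C2CCCCC2)c1` gives 264 nM. Compound 4 `COC(=O)/C=C/c1cccc(N(Cc2ccc(-c3cccc(OC(F)(F)F)c3)cc2)C(=O)C2CCCCC2)c1` has not yet been measured.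

Compound 2 differs from compound 1 by one change, (3-(trifluoromethoxy)phenyl in place of 4-(trifluoromethoxy)phenyl on an aromatic carbon), and the step for this change is a 1.1-fold higher number from compound 1 to compound 2 (0.05 log units; within the scatter). Compound 3 carries the same change as compound 4 does relative to it, (3-(trifluoromethoxy)phenyl in place of 4-(trifluoromethoxy)phenyl on an aromatic carbon), and the place lines of both changes read the same word for word, so this is the same change made on a second core. The two cores differ as described by cyclohexyl in place of isopropyl on a carbonyl carbon, and that step is a 1.2-fold higher number from compound 1 to compound 3 (0.08 log units; within the scatter). The values of compound 2 and compound 3 in this assay sit close together.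

Because the earlier step of a 1.1-fold higher number from compound 1 to compound 2 (0.05 log units; within the scatter) was small, the step for compound 4 is expected to be of about the same size, a 1.1-fold higher number from compound 3 to compound 4 (0.04 log units; within the scatter). Compound 4 is therefore estimated to give 290 nM, with a likely range from 150 nM to 560 nM; this rests on a single earlier example of the change.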

Compound 4, half-maximal effective concentration: 420 nM
Compound 4: middle estimate off by 1.4-fold (0.16 log units), on the low side; the measured number falls inside the stated range.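

Placing 3-(trifluoromethoxy)phenyl where 4-(trifluoromethoxy)phenyl stood, on the compounds carrying cyclohexyl, gives a 1.6-fold higher number from compound 3 to compound 4 (0.20 log units; within the scatter) in this assay, and this agrees with the first reading of the same change: the same change on two cores in this assay, a 1.1-fold higher number (0.05 log units; within the scatter) from compound 1 to compound 2 and a 1.6-fold higher number (0.20 log units; within the scatter) from compound 3 to compound 4, 1.4-fold (0.15 log units) apart, within the scatter of two such steps.

Exchanging isopropyl for cyclohexyl on the compounds carrying 3-(trifluoromethoxy)phenyl gives a 1.7-fold higher number from compound 2 to compound 4 (0.23 log units; within the scatter), which likewise agrees with its earlier reading: the same change on two cores in this assay, a 1.2-fold higher number (0.08 log units; within the scatter) from compound 1 to compound 3 and a 1.7-fold higher number (0.23 log units; within the scatter) from compound 2 to compound 4, 1.4-fold (0.15 log units) apart, within the scatter of two such steps.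

Within these four compounds, each change therefore carries over from one core to the other as far as the scatter can tell, but every step lies within that scatter, so this does not show that either change really alters the number, and two cores are too few for a general rule.

The compounds shown leave open whether the move behaves alike with a longer chain or a phenyl ring on the carbonyl carbon, or with a carboxylic acid in place of the methyl ester. They also leave open how a chlorine or a nitrile would fare in place of the trifluoromethoxy group.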